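Taking the Side Chain Off the Sulfur

This account rests on a few compounds, and the source may have more. Where it says the series, first, only, none or still open, it means among the compounds named here.

Among the measured compounds shown here, in a functional assay on HT cells (Homo sapiens) for antiproliferative activity, read by fluorescence, with a stated time of 72 h (a higher number here means a weaker inhibitor of growth, a lower number a stronger inhibitor of growth), compound 2 `CNCCSc1nc(NCc2ccc(-c3ccccn3)cc2)c2[nH]nc(C(C)C)c2n1` gives 56 nM, the lowest of the two numbers measured so far. For the measured compounds named here, the only other measured compound, compound 1 `CC(C)c1n[nH]c2c(NCc3ccc(-c4ccccn4)cc3)nc(SC3CCCC3O)nc12`, gives 567 nM. Compound 3 `CC(C)c1n[nH]c2c(NCc3ccc(-c4ccccn4)cc3)nc(S)nc12` has not yet been measured. It differs from compound 2 as follows: hydrogen in place of 2-(methylamino)ethyl on a sulfur. This leaves hydrogen in place of 2-(methylamino)ethyl on a sulfur. Going by the values given here, one measured step bears on this change: a 10-fold lower number from compound 1 to compound 2 (1.01 log units; beyond the scatter). That large step, beyond the scatter, came with 2-(methylamino)ethyl replacing 2-hydroxycyclopentyl on the same sulfur. Among the compounds with values here, it shows that the group on this sulfur can matter in this assay, but no measured compound has hydrogen there. A large rise is therefore expected, roughly back to the level of compound 1 at 567 nM. The estimated change is a 13-fold higher number from compound 2 to compound 3 (1.10 log units; beyond the scatter). For compound 3, the expected value is 700 nM, within an estimated range of 200 nM to 3000 nM.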

Compound 3, concentration for 50% growth inhibition: 2760 nM
Compound 3: the middle estimate sits 3.9-fold (0.60 log units) below what was measured, and the stated range covers the measured number.
By their numbers in this assay, from the lowest: compound 2; then compound 1; then compound 3.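

With hydrogen on the sulfur, the series gains its first reference point for having no side chain there. In this assay, losing the 2-(methylamino)ethyl gives a much larger change than the earlier exchange of side chains (a 49-fold higher number from compound 2 to compound 3 (1.69 log units; beyond the scatter)), and hydrogen also falls short of 2-hydroxycyclopentyl (a 4.9-fold higher number from compound 1 to compound 3 (0.69 log units; beyond the scatter)), so both compounds with a side chain on this sulfur are stronger inhibitors of growth than the compound with none. No measurement offered here bears on the reason for these differences.

The compounds shown leave open whether the advantage of compound 2 belongs to its amine or to the chain alone, which a plain ethyl or a 2-hydroxyethyl on the same sulfur would separate. As far as these compounds go, how a longer chain bearing an amine, or a chain ending in a carboxylic acid, would read also remains open.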